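The source may report more compounds than this note shows. Statements on the series, on what has been measured and on what is new or still open speak of the compounds shown alone.

Compound 2 `CC1(C)C=C(n2ccccc2=O)c2cc(O)ccc2O1` gives 5.31 in a functional assay (trachea) with Rattus norvegicus as the target (a lower number here means a less potent compound, a higher number a more potent compound, by a factor of ten per unit of this negative logarithm), the higher of the two numbers shown, but only by a number 0.26 log units higher from compound 1 to compound 2 (within the scatter), which lies within the scatter, compound 1 `CC1(C)C=C(n2ccccc2=O)c2ccccc2O1` giving 5.05. Compound 3 `CC1(C)C=C(n2ccccc2=O)c2cc(OC(=O)Nc3ccc(F)cc3)ccc2O1` differs from compound 2 by (4-fluorophenyl)carbamoyl in place of hydrogen on an oxygen on an aromatic ring. For the measured compounds named here, the single measured step, hydroxy in place of hydrogen, bears on it only loosely, and no measured step shows what a carbamoyl group on this oxygen does, so the direction is open. Compound 3 is therefore expected to show a step of a number 0.01 log units lower from compound 2 to compound 3 (within the scatter), an estimated 5.3 within the range 4.5 to 6.1.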

Compound 3, logarithm of the reciprocal of the active concentration, log(1/C): 4.37
Estimate against measurement, compound 3: 0.93 log units above, and the stated range ends above it.
By their numbers in this assay, from the lowest: compound 3; then compounds 1 and 2 (each within the scatter of the next).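

In this assay, for the compounds shown here, placing (4-fluorophenyl)carbamoyl on the oxygen on the aromatic ring gives a number 0.94 log units lower from compound 2 to compound 3 (beyond the scatter) and so produces the first change here that stands clear of the scatter. This oxygen therefore does not accept every substituent without cost, which the hydroxy step alone could not reveal. No measurement available here speaks to the reason for this loss.

Still open, from the compounds shown here alone, is whether a small group on this oxygen, such as methyl or acetyl, would keep the potency of compound 2. Whether the loss comes with the carbamoyl link or with the 4-fluorophenyl ring also remains unresolved.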